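Two Hydroxyls in Place of Bromo and Hydroxy

The source may report more compounds than this note shows. Statements on the series, on what has been measured and on what is new or still open speak of the compounds shown alone.

Among the compounds with values here, compound 3 `O=C(CSc1nnc(-c2ccncc2)o1)N/N=C/c1cc(Br)ccc1O` gives 9590 nM in a functional assay on BGC-823 cells (Homo sapiens) for cytotoxicity, read by MTT assay, with a stated time of 48 h (on this read-out lower numbers stand for stronger inhibition and higher numbers for weaker inhibition), the second highest of the three numbers so far. Compound 2 `O=C(CSc1nnc(-c2ccncc2)o1)N/N=C/c1cc(Cl)ccc1O` gives 5470 nM, which lies within the scatter of compound 3, while compound 1 `O=C(CSc1nnc(-c2ccncc2)o1)N/N=C/c1ccccc1` gives 22100 nM; the step is a 2.3-fold lower number from compound 1 to compound 3 (0.36 log units; beyond the scatter). Compound 4 `O=C(CSc1nnc(-c2ccncc2)o1)N/N=C/c1ccc(O)c(O)c1` carries the change (3,4-dihydroxyphenyl in place of 5-bromo-2-hydroxyphenyl on a carbon with a double bond to nitrogen). Within the data shown here, the steps that bear on it are a 4.0-fold lower number from compound 1 to compound 2 (0.61 log units; beyond the scatter) and a 2.3-fold lower number from compound 1 to compound 3 (0.36 log units; beyond the scatter), each showing that a hydroxyphenyl carrying chloro or bromo gives a lower number than plain phenyl; no measured step shows what two hydroxyls without a halogen do. The expected step is therefore a 1.2-fold lower number from compound 3 to compound 4 (0.08 log units; within the scatter), not beyond the scatter. For compound 4 the estimated value is 8000 nM, with a range from 2500 nM to 25000 nM.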

Compound 4, half-maximal inhibitory concentration: 1260 nM
Beside the measured number, compound 4's estimate is 6.3-fold (0.80 log units) above it, outside the stated range (below it).
By their numbers in this assay, from the lowest: compound 4; then compounds 2 and 3 (each within the scatter of the next); then compound 1.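

With a 7.6-fold lower number from compound 3 to compound 4 (0.88 log units; beyond the scatter) and a 4.3-fold lower number from compound 2 to compound 4 (0.64 log units; beyond the scatter) in this assay it becomes clear that an aryl group on this carbon with a double bond to nitrogen needs no chloro or bromo to give a low number: 3,4-dihydroxyphenyl carries neither. Against plain phenyl, an 18-fold lower number from compound 1 to compound 4 (1.24 log units; beyond the scatter) is the largest step seen at this position so far. Nothing available explains this drop. The compounds shown leave open whether both hydroxyls are needed, and whether 3,4-dimethoxyphenyl or 3,4-diaminophenyl in the same place would give a similar number.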